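The compounds below may be only part of what the source reports. "The series", "measured", "known", "first", "only" and "open" are said of these compounds alone.

Working notes on the series. Going by the values given here, in a functional assay on DU-145 cells (Homo sapiens) for cytotoxicity, read by trypan blue exclusion, with a stated time of 96 h (on this read-out higher numbers stand for weaker inhibition and lower numbers for stronger inhibition), compound 1 `COC(=O)CCNc1cc(CS(=O)(=O)/C=C/c2c(OC)cc(OC)cc2OC)ccc1OC` gives 1500 nM and compound 2 `COc1cc(OC)c(/C=C/S(=O)(=O)Cc2ccc(OC)c(NC(C(=O)O)c3ccc(Br)cc3)c2)c(OC)c1` gives 300 nM, the lower of the two numbers so far. Among the compounds with values here, the single measured step, a 5.0-fold lower number from compound 1 to compound 2 (0.70 log units; beyond the scatter), is modest but beyond the scatter. It puts (4-bromophenyl)(carboxy)methyl in place of 2-(methoxycarbonyl)ethyl on a nitrogen on an aromatic ring.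

Next is compound 3 `COc1ccc(C(Nc2cc(CS(=O)(=O)/C=C/c3c(OC)cc(OC)cc3OC)ccc2OC)C(=O)O)cc1`, which differs from compound 2 by methoxy in place of bromo on an aromatic carbon. This is methoxy in place of bromo on an aromatic carbon, para to a large group. The rest of the structure is unchanged.

The step of a 5.0-fold lower number from compound 1 to compound 2 (0.70 log units; beyond the scatter) bears on this only loosely, since it replaces the whole substituent on the nitrogen and leaves the bromo itself untested. Within the data shown here, no measured pair varies this position, so the data give no direction for the swap, and no change beyond the scatter is expected in this assay. The step is estimated as a 1.2-fold lower number from compound 2 to compound 3 (0.08 log units; within the scatter). With so little to go on, the range is kept wide. For compound 3 the expected value is 250 nM, with an estimated range of 80 nM to 800 nM.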

Compound 3, half-maximal inhibitory concentration: 100 nM
The estimate for compound 3 lay 2.5-fold (0.40 log units) above the measured number; measured number inside the range.
By their numbers in this assay, from the lowest: compound 3; then compound 2; then compound 1.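

Going by these compounds alone, replacing bromo with methoxy on this aromatic carbon, para to a large group, gives in this assay a 3.0-fold lower number from compound 2 to compound 3 (0.48 log units; beyond the scatter) and is the first measured change that leaves the rest of the structure untouched, so this position does affect the number even though the earlier step left it untested. Against the 2-(methoxycarbonyl)ethyl compound, carboxy(4-methoxyphenyl)methyl on the nitrogen gives a 15-fold lower number from compound 1 to compound 3 (1.18 log units; beyond the scatter) and is now a large step, whereas the 4-bromophenyl version was only a modest one; that step replaces the whole substituent, so it cannot be divided among the parts of the group. No measurement in hand explains why methoxy gives the lower number in this pair.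

With only bromo and methoxy read here, the compounds shown leave open how a hydroxy group, a chloro group or an amine on this carbon would compare with those two. They also leave open whether the difference between 4-methoxyphenyl and 4-bromophenyl persists when the carboxylic acid of that side chain becomes a methyl ester or an amide.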